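The source may report more compounds than this note shows. Statements on the series, on what has been measured and on what is new or still open speak of the compounds shown alone.

Compound 1 `Cc1cccc(NC(=O)COc2ccc(/C=C3\SC(=O)NC3=O)cc2)n1`: 28300 nM
Compound 2 `O=C(COc1ccc(/C=C2\SC(=O)NC2=O)cc1)Nc1ccc(F)cc1`: 54600 nM
Compound 3 `O=C(COc1ccc(/C=C2\SC(=O)NC2=O)cc1)Nc1ccc(Br)cc1`: 55100 nM

In a functional assay on MCF7 cells (Homo sapiens) for inhibition (a higher number here means a weaker inhibitor of growth, a lower number a stronger inhibitor of growth), compound 2 stands second highest of the three numbers, and both neighbours lie within the scatter of it: towards compound 3 the step is a 1.0-fold higher number from compound 2 to compound 3 (0.00 log units; within the scatter), and from compound 1 the step is a 1.9-fold higher number from compound 1 to compound 2 (0.29 log units; within the scatter). Compound 4 `O=C(COc1ccc(/C=C2\SC(=O)NC2=O)cc1)Nc1ccc(F)cc1F` differs from compound 2 by fluoro in place of hydrogen on an aromatic carbon, so the 4-fluorophenyl becomes a 2,4-difluorophenyl. Among the compounds with values here, no measured pair adds a second fluoro to this ring, so the guidance is indirect. The nearest comparison is the exchange of one halogen for another on the same ring, a 1.0-fold higher number from compound 2 to compound 3 (0.00 log units; within the scatter), which stayed within the scatter, and even replacing the whole aromatic group on the amide nitrogen, a 1.9-fold higher number from compound 1 to compound 3 (0.29 log units; within the scatter), moved the number only within the scatter. Three quite different groups at this position thus give numbers close together, which points to no step beyond the scatter for a further fluoro. Compound 4 is therefore expected to give about 55000 nM in this assay, with a range from 25000 nM to 120000 nM. This estimate means a step of a 1.0-fold higher number from compound 2 to compound 4 (0.00 log units; within the scatter).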

Compound 4, concentration for 50% growth inhibition: 65800 nM
Compound 4: the middle estimate sits 1.2-fold (0.08 log units) below what was measured; the range from low to high includes it.
By their numbers in this assay, from the lowest: compounds 1, 2, 3 and 4 (each within the scatter of the next, the first and the last beyond it).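

In this assay, a second fluoro on the ring, ortho to a large group, gives a 1.2-fold higher number from compound 2 to compound 4 (0.08 log units; within the scatter), so this position accepts a fluoro without a step that can be told from the scatter, and the exchange of 4-bromophenyl for 2,4-difluorophenyl, at a 1.2-fold higher number from compound 3 to compound 4 (0.08 log units; within the scatter), reads the same way. Within the data shown here, the new compound also gives the first step at this amide nitrogen that passes the scatter, though only modestly: a 2.3-fold higher number from compound 1 to compound 4 (0.37 log units; beyond the scatter), while the steps from compound 1 to the two singly halogenated compounds stayed within it. Nothing measured here accounts for this small difference.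

From the compounds shown here alone, whether the methyl or the ring nitrogen of the 6-methylpyridin-2-yl group matters remains open. So does the outcome of an amine or a carboxylic acid on this ring.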